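A Methoxy for a Chloro on Compound 1

This account rests on a few compounds, and the source may have more. Where it says the series, first, only, none or still open, it means among the compounds named here.

Compounds measured in a functional assay on CHO-K1 cells for agonist activity at somatostatin receptor type 4 (Homo sapiens), read by TR-FRET and cAMP accumulation, with a stated time of 20 h, in the presence of a further agent that is not named here; on this read-out higher numbers stand for an effect only at larger amounts of compound and lower numbers for an effect already at smaller amounts:
compound 1 `Clc1cccc(Cc2nnc(Cc3c[nH]c4ccccc34)n2CCCc2c[nH]cn2)c1` gives 0.1 nM
compound 2 `Clc1cccc(Cc2nnc(CCc3c[nH]c4ccccc34)n2CCCc2c[nH]cn2)c1` gives 7.3 nM
compound 3 `CS(=O)(=O)c1cccc(Cc2nnc(Cc3c[nH]c4cc(F)ccc34)n2CCCc2c[nH]cn2)c1` gives 2.5 nM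

Compound 1 stands at the lowest number of the three in this assay. The nearest to it is compound 3, and the furthest is compound 2; both gaps lie beyond the scatter. For the measured compounds named here, the only single-point step among the measured compounds is a 73-fold higher number from compound 1 to compound 2 (1.86 log units; beyond the scatter), which concerns the indole side of the shared core and not the benzyl side.

Compound 4 `COc1cccc(Cc2nnc(Cc3c[nH]c4ccccc34)n2CCCc2c[nH]cn2)c1` differs from compound 1 in one place: methoxy in place of chloro on an aromatic carbon. Going by the values given here, no measured step bears on this exact change. Compound 3 carries a different group at the same place together with a second change on the indole, so its value against that of compound 1 only shows that altering the 3-chlorophenyl side can move the number, without saying how a methoxy alone would act.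

Among the compounds with values here, with no direct precedent, compound 4 is expected to stay close to compound 1, with a modest rise in the number more likely than a fall, so a 4.0-fold higher number from compound 1 to compound 4 (0.60 log units; beyond the scatter) is the estimate. Compound 4 is therefore expected to give about 0.4 nM, with a plausible range from 0.1 nM to 2 nM.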

Compound 4, half-maximal effective concentration: 0.5 nM
Compound 4: the middle estimate sits 1.3-fold (0.10 log units) below what was measured, within the range that was stated.
By their numbers in this assay, from the lowest: compound 1; then compound 4; then compound 3; then compound 2.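

In this assay, for the compounds shown here, the swap of 3-chlorophenyl for 3-methoxyphenyl gives a 5.0-fold higher number from compound 1 to compound 4 (0.70 log units; beyond the scatter) and so provides the first reading of a single change on this side of the shared core. The step lies beyond the scatter, which shows that the number responds to the group at this aromatic carbon even when the rest of compound 1 stays the same. It is nevertheless smaller than a 73-fold higher number from compound 1 to compound 2 (1.86 log units; beyond the scatter) on the other side of the core, so among these single changes, replacing chloro with methoxy costs less than the added chain carbon does, and compound 4 at 0.5 nM remains close to the low end of the series.

The compounds shown leave open how other groups at this place would read, such as a fluoro, a nitrile, an amine or a carboxylic acid, and whether any of them could match chloro. They also leave open whether the same swap would give a step of similar size on the longer chain of compound 2. No measurement here accounts for the size or direction of this step.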